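Thiophenyl in place of fluorophenyl on the shared core

This account rests on a few compounds, and the source may have more. Where it says the series, first, only, none or still open, it means among the compounds named here.

Two compounds have numbers in an assay on microsomes from liver for inhibition of 3-hydroxy-3-methylglutaryl-coenzyme A reductase (Rattus norvegicus); a higher number here means a weaker inhibitor, a lower number a stronger inhibitor. Compound 1 `O=C(O)C[C@H](O)C[C@H](O)CCn1c(C(F)(F)F)nc(-c2ccc(F)cc2)c1-c1ccc(F)cc1` gives 38 nM. Compound 2 `COc1ccc(-c2nc(C(F)(F)F)n(CC[C@@H](O)C[C@@H](O)CC(=O)O)c2-c2ccc(F)cc2)cc1`, with methoxy in place of fluoro on an aromatic carbon, gives 68 nM. Among the compounds with values here, the one measured step, a 1.8-fold higher number from compound 1 to compound 2 (0.25 log units; within the scatter), is within the scatter, so compound 1 and compound 2 cannot be told apart on this assay, and compound 1 simply has the smaller of the two numbers without that meaning a real difference.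

Compound 3 `O=C(O)C[C@H](O)C[C@H](O)CCn1c(C(F)(F)F)nc(-c2ccc(F)cc2)c1-c1cccs1` differs from compound 1 by thiophen-2-yl in place of 4-fluorophenyl on an aromatic carbon. Within the data shown here, no measured step concerns this kind of change; the single step available describes a different substitution and was itself within the scatter. There is thus no basis for expecting more than a small move in this assay, in either direction. Compound 3 is expected to give about 60 nM, with a range of 20 nM to 200 nM. For compound 3 the estimated step is a 1.6-fold higher number from compound 1 to compound 3 (0.20 log units; within the scatter), within or near the scatter.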

Compound 3, half-maximal inhibitory concentration: 215 nM
The estimate for compound 3 lay 3.6-fold (0.55 log units) below the measured number; the whole stated range lies below it.
By their numbers in this assay, from the lowest: compounds 1 and 2 (each within the scatter of the next); then compound 3.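

At the aromatic carbon next to the ring atom that bears a 6-carboxy-3,5-dihydroxyhexyl group, the series does not tolerate every aromatic ring equally: in this assay, thiophen-2-yl in place of 4-fluorophenyl gives a 5.7-fold higher number from compound 1 to compound 3 (0.75 log units; beyond the scatter). Within the data shown here, this is the first step beyond the scatter, whereas methoxy in place of fluoro on the other 4-fluorophenyl group gives a 1.8-fold higher number from compound 1 to compound 2 (0.25 log units; within the scatter). No measurement bearing on the origin of this loss is available.

With a single replacement at this position, the step cannot be divided between removal of the fluoro substituent and the change from a six-membered to a five-membered ring. A plain phenyl group or a thiophen-3-yl group at the same carbon would separate these two changes, and a 4-methoxyphenyl group there would test whether methoxy is tolerated at this position too.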